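Aryl swaps on the alkyne of the amide series

The source may hold more compounds than are shown below. What is called first, only, known or untested is meant among the compounds shown, and "the series" means these compounds.

Compound 2 `Cc1cccc(C#Cc2ccc(C(=O)N[C@H](C)C(C)(C)O)nc2)c1` gives 68.6% in a functional assay on HEK293 cells for positive allosteric modulation of metabotropic glutamate receptor 5 (Rattus norvegicus), read by fluorescence and calcium flux (a lower number here means a smaller maximal response, a higher number a larger maximal response), and compound 1 `C[C@@H](NC(=O)c1ccc(C#Cc2ccccc2F)cn1)C(C)(C)O` gives 60%. Within the data shown here, the only measured step, a number 8.6 percentage points higher from compound 1 to compound 2 (within the scatter), exchanges the aryl on the triple-bonded carbon and stays within the scatter. Compound 3 `C[C@@H](NC(=O)c1ccc(C#Cc2cccnc2)cn1)C(C)(C)O` carries the change (pyridin-3-yl in place of 3-methylphenyl on a triple-bonded carbon), again on the triple-bonded carbon, so that earlier step is the one that bears on it. With that step inside the scatter, no step beyond the scatter is expected in this assay. The step expected from compound 2 to compound 3 is a number 6.6 percentage points lower from compound 2 to compound 3 (within the scatter). For compound 3 the expected value is 62%, in the range 42% to 82%.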

Compound 3, largest response reached (reported as efficacy), in percent of the reference or control that the assay uses: 71.5%
Beside the measured number, compound 3's estimate is 9.5 percentage points below it, and the stated range covers the measured number.
By their numbers in this assay, from the lowest: compounds 1, 2 and 3 (each within the scatter of the next, the first and the last beyond it).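

On the triple-bonded carbon, a ring carrying a nitrogen holds the response in this assay: pyridin-3-yl in place of 3-methylphenyl gives a number 2.9 percentage points higher from compound 2 to compound 3 (within the scatter) and adds a hydrogen-bond acceptor. Among these compounds, the same position now also gives the first step beyond the scatter, a number 11.5 percentage points higher from compound 1 to compound 3 (beyond the scatter), for pyridin-3-yl in place of 2-fluorophenyl, though it is modest. Nothing at hand accounts for either step.

Still open, on these data alone, is whether a cyclohexyl or an aminophenyl group on the triple-bonded carbon keeps this response in this assay. Also open, as far as these compounds go, is how the series answers a change elsewhere on the shared core.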